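Swapping a Bromophenyl for a Cyclopropyl Group

The compounds below may be only part of what the source reports. "The series", "measured", "known", "first", "only" and "open" are said of these compounds alone.

Of the compounds shown here, three have so far been measured in an ADME assay on HeLa cells (Homo sapiens) for cytotoxicity, read by sulforhodamine B assay, with a stated time of 48 h, tested at 10 uM; a higher number here means more inhibition at the concentration tested (going by the name of the read-out), a lower number less inhibition. Compound 1 `COc1nc2ccc(Br)cc2cc1C(c1ccccc1)n1cc(-c2ccc(Br)cc2)nn1` gives 6.92% there, compound 2 `COc1nc2ccc(Br)cc2cc1C(c1ccccc1)n1cc(-c2ccc(F)cc2)nn1` gives 4.27%, and compound 3 `COc1nc2ccc(Br)cc2cc1C(c1ccccc1)n1cc(CCCCCO)nn1` gives 1.08%. Within the data shown here, compound 1 holds the highest of the three numbers, but the steps to the other two, a number 2.7 percentage points lower from compound 1 to compound 2 (within the scatter) and a number 5.8 percentage points lower from compound 1 to compound 3 (within the scatter), both lie within the scatter, as does a number 3.2 percentage points lower from compound 2 to compound 3 (within the scatter); on these numbers no compound's inhibition in this assay can be called higher or lower than another's.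

Compound 4 `COc1nc2ccc(Br)cc2cc1C(c1ccccc1)n1cc(C2CC2)nn1` has not yet been measured. It differs from compound 1 in one place: cyclopropyl in place of 4-bromophenyl on an aromatic carbon. The measured steps that bear on this change are those in which the same 4-bromophenyl was exchanged, namely a number 5.8 percentage points lower from compound 1 to compound 3 (within the scatter), where a 5-hydroxypentyl entered, and the smaller a number 2.7 percentage points lower from compound 1 to compound 2 (within the scatter), where only the bromo gave way to fluoro. Neither exchange moved this assay beyond the scatter, and all three values sit close to the bottom of the scale. The expectation for compound 4 is therefore a step of a number 3.9 percentage points lower from compound 1 to compound 4 (within the scatter), no larger than the scatter. Compound 4 is estimated at 3%, with a range from -4% to 10%.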

Compound 4, a percentage reported as inhibition, at one concentration (the size of the read-out at that concentration, not a potency): -5.84%
For compound 4 the middle estimate is 8.8 percentage points above the measured one; the whole stated range lies above it.
By their numbers in this assay, from the lowest: compounds 4, 3, 2 and 1 (each within the scatter of the next, the first and the last beyond it).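

Among these compounds, at this position, on an aromatic carbon of the five-membered ring with three nitrogens, cyclopropyl provides the first steps in this assay that exceed the scatter: a number 12.8 percentage points lower from compound 1 to compound 4 (beyond the scatter) and a number 10.1 percentage points lower from compound 2 to compound 4 (beyond the scatter) are both readable, though modest, whereas none of the exchanges among the earlier compounds could be told apart. The separation is not complete, since a number 6.9 percentage points lower from compound 3 to compound 4 (within the scatter) leaves compound 4 unresolved from the 5-hydroxypentyl compound, so that the change can be read only against the two compounds carrying a halogenated phenyl ring. The data offer no measured explanation for why cyclopropyl differs from these two aryl groups in this way.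

On these data alone, it remains open whether the difference follows from losing the six-membered aromatic ring or is specific to cyclopropyl, a question that an unsubstituted phenyl, a cyclohexyl or a simple methyl at the same carbon could address. Also open, as far as these compounds go, is how an amine or a carboxylic acid on this carbon would read in this assay, and whether any group here can lift the number well clear of the low values seen so far.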